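This account rests on a few compounds, and the source may have more. Where it says the series, first, only, none or still open, it means among the compounds named here.

Of the compounds shown here, two of a shared core have been tested so far. Compound 1 `O=C(/C=C/c1ccc2c(c1)B(O)OC2)c1ccccc1` gives 3400 nM in a functional assay on SK-OV-3 cells (Homo sapiens) for cytotoxicity, read by MTT assay, with a stated time of 48 h; a higher number here means a weaker inhibitor, a lower number a stronger inhibitor. For the measured compounds named here, compound 2 `O=C(/C=C/c1ccc2c(c1)B(O)OC2)c1ccc(Br)cc1` gives 4500 nM in this assay, so compound 2 is one of only two measured compounds, and its number and that of compound 1 lie within the scatter of each other, as the step of a 1.3-fold higher number from compound 1 to compound 2 (0.12 log units; within the scatter) shows.

The next compound, compound 3 `O=C(/C=C/c1ccc2c(c1)B(O)OC2)c1ccc([N+](=O)[O-])cc1`, differs from compound 2 in one place: nitro in place of bromo on an aromatic carbon. Going by the values given here, the only measured step, a 1.3-fold higher number from compound 1 to compound 2 (0.12 log units; within the scatter), concerns the same aromatic carbon, where bromo replaced hydrogen without moving the number beyond the scatter. Among the compounds with values here, no measured step shows nitro at this place or anywhere else, so there is no direct guide to how nitro compares with bromo here. Given that the one change at this carbon left the number essentially unchanged, the expectation for compound 3 is a step of no clear size in this assay.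

For compound 3 the value in this assay is estimated at 4500 nM, within a range from 2000 nM to 10000 nM. This estimate corresponds to an expected step of no change at the digits printed from compound 2 to compound 3 (within the scatter), which is expected to stay within the scatter.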

Compound 3, half-maximal inhibitory concentration: 7900 nM
For compound 3 the middle estimate is 1.8-fold (0.24 log units) below the measured one; low and high end bracket the measured number.
By their numbers in this assay, from the lowest: compounds 1, 2 and 3 (each within the scatter of the next, the first and the last beyond it).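

Swapping bromo for nitro on this aromatic carbon, para to a large group, gives a 1.8-fold higher number from compound 2 to compound 3 (0.24 log units; within the scatter) in this assay, so this swap alone does not clearly separate the two groups. For the compounds shown here, the comparison with hydrogen at the same carbon shows more: nitro gives a 2.3-fold higher number from compound 1 to compound 3 (0.37 log units; beyond the scatter), the first step at this position to pass beyond the scatter, and it is a modest move towards a weaker inhibitor, whereas bromo gave only a 1.3-fold higher number from compound 1 to compound 2 (0.12 log units; within the scatter). So this carbon does not tolerate every replacement of hydrogen equally well in this cell assay, although the effect so far is small, and nothing available here explains the difference.

On these data alone, whether an amine, a carboxylic acid or a methoxy group on this carbon would push the number higher still, or bring it below that of compound 1, remains open. As far as these compounds go, it is also open whether nitro would give a similar step on another carbon of this six-membered aromatic ring, since all three compounds carry their change at the same place.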